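The source may hold more compounds than are shown below. What is called first, only, known or untested is meant among the compounds shown, and "the series" means these compounds.

Values measured in an ADME assay on HEK293 cells (Homo sapiens) for cytotoxicity, read by MTT assay, with a stated time of 72 h; on this read-out lower numbers stand for stronger inhibition and higher numbers for weaker inhibition:
Compound 1 `O=C(CN1CCN(C(=O)c2ccccc2)CC1)N1CCN(CCCc2c[nH]c3ccccc23)CC1`: > 200000 nM (a limit of the assay)
Compound 2 `O=C(CN1CCN(C(=O)c2ccc(Cl)cc2)CC1)N1CCN(CCCc2c[nH]c3ccccc23)CC1`: 98200 nM
Compound 3 `O=C(CN1CCN(C(=O)c2ccc(F)cc2)CC1)N1CCN(CCCc2c[nH]c3ccccc23)CC1`: 141000 nM

For the measured compounds named here, compound 3 reads 141000 nM, and the only other number available is close to it. The gap, a 1.4-fold higher number from compound 2 to compound 3 (0.16 log units; within the scatter), does not allow the two compounds to be ranked. Compound 1 is known only as a limit, > 200000 nM.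

The next compound is compound 4 `COc1cccc(C(=O)N2CCN(CC(=O)N3CCN(CCCc4c[nH]c5ccccc45)CC3)CC2)c1`. It keeps the shared core of compound 3 and carries 3-methoxyphenyl in place of 4-fluorophenyl on a carbonyl carbon. Going by the values given here, no measured step makes this exact exchange, so the guidance comes from the other changes on the same aromatic group. These are an at least 2.0-fold lower number from compound 1 to compound 2 (0.30 log units; that floor lies within the scatter) and an at least 1.4-fold lower number from compound 1 to compound 3 (0.15 log units; that floor lies within the scatter). Both are floors rather than exact sizes, and neither goes beyond the scatter. Among these three compounds, then, no change on this group has been shown to move the number beyond the scatter, and no direction is expected in this assay for the new exchange. The expected step is a 1.0-fold lower number from compound 3 to compound 4 (0.00 log units; within the scatter), which is none beyond the scatter. For compound 4 the estimate is 140000 nM, with an expected range from 70000 nM to 250000 nM.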

Compound 4, half-maximal inhibitory concentration: 143000 nM
Compound 4: middle estimate off by 1.0-fold (0.01 log units), on the low side; the measured number falls inside the stated range.
By their numbers in this assay, from the lowest: compounds 2, 3 and 4 (each within the scatter of the next). At a limit, above all of these: compound 1.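

In this assay, the exchange on a carbonyl carbon now brings in a group of another kind: 3-methoxyphenyl carries an oxygen and a hydrogen-bond acceptor that 4-fluorophenyl lacks, yet the result is a 1.0-fold higher number from compound 3 to compound 4 (0.01 log units; within the scatter), and the comparison with 4-chlorophenyl gives a 1.5-fold higher number from compound 2 to compound 4 (0.16 log units; within the scatter). The earlier measured values covered only the two halogen-bearing phenyl groups, so compound 4 extends the absence of any resolved difference among the substituted compounds beyond halogens. Methoxy in place of hydrogen gives an at least 1.3-fold lower number from compound 1 to compound 4 (0.14 log units; that floor lies within the scatter), which can be read only as a floor because the starting number is a limit of the assay: the limit of > 200000 nM in this assay, at which 1 of the 4 values shown sits.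

From the compounds shown here alone, whether an amine or a carboxylic acid on this aromatic ring, or a longer chain in place of the methoxy, would move the number beyond the scatter remains open. Also open, going by these compounds, is whether any change to the shared core, rather than to this group, would shift the reading in this assay.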